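Fluoro added to the phenyl of a hydroxamic acid

The source may hold more compounds than are shown below. What is called first, only, known or untested is meant among the compounds shown, and "the series" means these compounds.

Compound 1 `O=C(CCCCCc1nc2ccccc2[nH]1)NO` gives 11000 nM in a functional assay on SK-OV-3 cells (Homo sapiens) for cytotoxicity; a lower number here means a stronger inhibitor, a higher number a weaker inhibitor.
Compound 2 `O=C(CCCCCCc1nc2ccc(Cl)cc2[nH]1)NO` gives 320 nM in this assay.
Compound 3 `O=C(CCCCCCc1nc2ccc(-c3ccccc3)cc2[nH]1)NO` gives 100 nM in this assay.

Compound 3 holds the lowest number of the three; the step of a 3.2-fold lower number from compound 2 to compound 3 (0.51 log units; beyond the scatter) separates it from compound 2, and compound 1 sits far higher. Compound 4 `O=C(CCCCCCc1nc2ccc(-c3cccc(F)c3)cc2[nH]1)NO` differs from compound 3 by fluoro in place of hydrogen on an aromatic carbon. Among the compounds with values here, no measured step concerns this change: the one step that is known, a 3.2-fold lower number from compound 2 to compound 3 (0.51 log units; beyond the scatter), swaps chloro for phenyl on the shared core and says nothing about a fluoro on the phenyl itself. A step within the scatter, no change at the digits printed from compound 3 to compound 4 (within the scatter), is therefore expected. Compound 4 is estimated at 100 nM, in a range from 40 nM to 250 nM.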

Compound 4, half-maximal inhibitory concentration: 1500 nM
Compound 4: the middle estimate sits 15-fold (1.18 log units) below what was measured; the whole stated range lies below it.
By their numbers in this assay, from the lowest: compound 3; then compound 2; then compound 4; then compound 1.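

In this assay, the added phenyl of compound 3 proves far from indifferent to substitution: 3-fluorophenyl in place of phenyl gives a 15-fold higher number from compound 3 to compound 4 (1.18 log units; beyond the scatter). The advantage phenyl held over chloro is more than lost, as 3-fluorophenyl in place of chloro gives a 4.7-fold higher number from compound 2 to compound 4 (0.67 log units; beyond the scatter). Nothing available explains why this fluoro has so large an effect. Going by these compounds, it remains open whether the loss is particular to fluoro or would follow a methoxy group or an amine at the same place. Equally open, on these data alone, is how fluoro would behave elsewhere on the phenyl.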